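The source may report more compounds than this note shows. Statements on the series, on what has been measured and on what is new or still open speak of the compounds shown alone.

The series shares the core of compound 1 `CCN(Cc1ccc(OCCN2C(=O)CCC2=O)c(C)c1)C(CC(=O)O)c1ccc(Cl)cc1`, which in an assay on CHO cells for displacement of a labelled ligand from C-X-C chemokine receptor type 3 (Homo sapiens), with a stated time of 60 min (on this read-out lower numbers stand for stronger inhibition and higher numbers for weaker inhibition), gives 424 nM. Compound 2 `Cc1cc(CN(CC2CC2)[C@@H](CC(=O)O)c2ccc(Cl)cc2)ccc1OCCN1C(=O)CCC1=O` gives 42 nM in this assay, and compound 3 `Cc1cc(CN(CC2CCCC2)C(CC(=O)O)c2ccc(Cl)cc2)ccc1OCCN1C(=O)CCC1=O` gives 71 nM. Going by the values given here, the single step measured in one place, a 6.0-fold lower number from compound 1 to compound 3 (0.78 log units; beyond the scatter), shows that cyclopentyl in place of methyl on a saturated chain carbon bound to an amine nitrogen brings a clear gain. Compound 3 therefore stands second highest of the three numbers: compound 2 is its nearest neighbour, within the scatter, while compound 1 lies well apart, beyond it. Compound 4 `Cc1cc(CN(CC2CCCC2)[C@@H](CC(=O)O)c2ccc(Cl)cc2)ccc1OCCN1C(=O)CCC1=O` has the same atoms and bonds as compound 3; (the two compounds have the same atoms and bonds; at least one stereo element is drawn with a configuration in one of them and without one in the other: 1 of 1 stereo elements differ; a stereocentre at a saturated chain carbon is drawn without a configuration in compound 3 and S in compound 4). Among the compounds with values here, no measured step alters a stereo element on its own, so none bears directly on this change, though compound 2 is also drawn as S. Because compound 3 gives 71 nM while drawn without a configuration, a step of a 1.8-fold lower number from compound 3 to compound 4 (0.25 log units; within the scatter) toward a lower number is expected. Compound 4 is thus estimated at 40 nM in this assay, ranging from 15 nM to 120 nM.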

Compound 4, half-maximal inhibitory concentration: 36 nM
Beside the measured number, compound 4's estimate is 1.1-fold (0.05 log units) above it, within the range that was stated.
By their numbers in this assay, from the lowest: compounds 4, 2 and 3 (each within the scatter of the next); then compound 1.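

In this assay the first direct test of the stereocentre at the saturated chain carbon yields a 2.0-fold lower number from compound 3 to compound 4 (0.29 log units; within the scatter) and so drawing it as S gives no difference clear of the scatter. This step compares a defined drawing with an undefined one, not one configuration with the other, because of how the pair is drawn: the fact that one of compounds 3 and 4 is drawn with a defined configuration and the other without, at the place where they differ. With both compounds drawn S, cyclopentyl and cyclopropyl on a saturated chain carbon bound to an amine nitrogen can be compared directly, and the result is a 1.2-fold lower number from compound 2 to compound 4 (0.07 log units; within the scatter) with the two groups not told apart in this range. The compounds shown leave open how the R configuration at the stereocentre compares with S. They also leave open how an isopropyl group or a cyclohexyl ring would read in place of cyclopentyl.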